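The source may report more compounds than this note shows. Statements on the series, on what has been measured and on what is new or still open speak of the compounds shown alone.

Of the compounds shown here, three sharing one core have been tested in a functional assay on DU-145 cells (Homo sapiens) for cytotoxicity, read by MTT assay; on this read-out lower numbers stand for stronger inhibition and higher numbers for weaker inhibition. Compound 1 `CC[C@@](C)(O)CC(=O)O[C@H](CC=C(C)C)C1=CC(=O)c2c(O)ccc(O)c2C1=O` gives 12700 nM. Compound 2 `CCCC(C)(O)CC(=O)O[C@H](CC=C(C)C)C1=CC(=O)c2c(O)ccc(O)c2C1=O` gives 75000 nM. Compound 3 `CCCC(CC(=O)O[C@H](CC=C(C)C)C1=CC(=O)c2c(O)ccc(O)c2C1=O)OC(C)=O` gives 55700 nM, which is the second highest of the three numbers; its nearest neighbour is compound 2, and the gap between them, a 1.3-fold lower number from compound 2 to compound 3 (0.13 log units; within the scatter), lies within the scatter, while its furthest is compound 1, from which it is separated by a 4.4-fold higher number from compound 1 to compound 3 (0.64 log units; beyond the scatter).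

The next compound, compound 4 `CCCCCCC(C)(O)CC(=O)O[C@H](CC=C(C)C)C1=CC(=O)c2c(O)ccc(O)c2C1=O`, differs from compound 3 at one place: 1-hydroxy-1-methylheptyl in place of 1-acetoxybutyl on a saturated chain carbon bound to a carbonyl carbon. For the measured compounds named here, two measured steps bear on this change. The step of a 4.4-fold higher number from compound 1 to compound 3 (0.64 log units; beyond the scatter) shows that swapping a 1-hydroxy-1-methylpropyl for a 1-acetoxybutyl raised the number, whereas a 1.3-fold lower number from compound 2 to compound 3 (0.13 log units; within the scatter) shows that the same swap from a 1-hydroxy-1-methylbutyl made no difference beyond the scatter. Lengthening the chain by one carbon, a 5.9-fold higher number from compound 1 to compound 2 (0.77 log units; beyond the scatter), raised the number. Compound 4 both returns to a hydroxy-methyl group and lengthens the chain considerably, so these two tendencies pull in opposite directions.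

On balance, compound 4 is expected to sit close to compound 3, with a step of about a 1.1-fold higher number from compound 3 to compound 4 (0.03 log units; within the scatter), and its value in this assay is estimated at 60000 nM, within a range from 15000 nM to 200000 nM.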

Compound 4, half-maximal inhibitory concentration: > 100000 nM
Compound 4: only a limit was reported (the forecaster's own chance of this, stated with the estimate: 15%); middle value at least 1.6-fold (0.22 log units) from the limit.
By their numbers in this assay, from the lowest: compound 1; then compounds 3 and 2 (each within the scatter of the next). At a limit, above all of these: compound 4.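

In this assay, compound 4, which carries the 1-hydroxy-1-methylheptyl group, is reported only as a limit: the limit of > 100000 nM in this assay, at which 1 of the 4 values shown sits. For the compounds shown here, compounds 1 and 4 differ in one place, and an at least 7.8-fold higher number from compound 1 to compound 4 (0.89 log units; beyond the scatter) shows that replacing 1-hydroxy-1-methylpropyl with this much longer chain leaves the number clearly higher, whereas the earlier compounds showed only the effect of adding a single carbon. The other two comparisons are less decisive, since the floors of an at least 1.3-fold higher number from compound 2 to compound 4 (0.12 log units; that floor lies within the scatter) and an at least 1.7-fold higher number from compound 3 to compound 4 (0.25 log units; that floor lies within the scatter) both lie within the scatter, so the true gaps could be negligible or large, and compound 4 cannot yet be placed firmly against compound 2 or compound 3.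

The limit also leaves open how far the number rises with chain length, and whether an intermediate chain such as 1-hydroxy-1-methylpentyl would read closer to compound 2 or to compound 4. As far as these compounds go, it remains equally open how this position would respond to an amine or a carboxylic acid in place of the hydroxy group, or to a phenyl ring in place of the long chain.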